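The source may hold more compounds than are shown below. What is called first, only, known or untested is meant among the compounds shown, and "the series" means these compounds.

Measured so far:
Compound 1 `Cn1c(/C=C2\SC(=O)N(CC(=O)Nc3cc(C(C)(C)C)on3)C2=O)nc2ccccc21` gives 33800 nM in a functional assay on MDA-MB-231 cells (Homo sapiens) for inhibition, read by MTT assay, with a stated time of 48 h; on this read-out lower numbers stand for stronger inhibition and higher numbers for weaker inhibition.
Compound 2 `Cn1c(/C=C2\SC(=O)N(CC(=O)N3CCOCC3)C2=O)nc2ccccc21` gives > 50000 nM in this assay, which is a limit of the method rather than a number.
Compound 3 `CCn1c(/C=C2\SC(=O)N(CC(=O)Nc3cc(C(C)(C)C)on3)C2=O)nc2ccccc21` gives > 50000 nM in this assay, again a limit rather than a number.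

Within the data shown here, two of the three values sit at the limit of > 50000 nM in this assay, at which 2 of the 3 values shown sit, so compound 1 supplies the only outright number in this assay. Compound 4 `Cn1c(/C=C2\SC(=O)N(CC(=O)Nc3nc(-c4ccccc4)cs3)C2=O)nc2ccccc21` differs from compound 1 by 4-phenyl-1,3-thiazol-2-yl in place of 5-(tert-butyl)-1,2-oxazol-3-yl on an amide-type nitrogen. Two measured steps give some guidance. The replacement at the same amide position gave an at least 1.4-fold higher number from compound 1 to compound 2 (0.17 log units; that floor lies within the scatter), and the change on the saturated chain carbon gave an at least 1.4-fold higher number from compound 1 to compound 3 (0.17 log units; that floor lies within the scatter); both are floors that lie within the scatter, so neither shows a step that is clearly beyond it. Compound 4 is therefore expected to show no change beyond the scatter, a 1.1-fold lower number from compound 1 to compound 4 (0.05 log units; within the scatter). The expected value of compound 4 is 30000 nM, within a range from 8000 nM to 90000 nM.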

Compound 4, half-maximal inhibitory concentration: 29200 nM
Estimate against measurement, compound 4: 1.0-fold (0.01 log units) above; the measured number falls inside the stated range.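

At the amide-type nitrogen, 4-phenyl-1,3-thiazol-2-yl in place of 5-(tert-butyl)-1,2-oxazol-3-yl gives a 1.2-fold lower number from compound 1 to compound 4 (0.06 log units; within the scatter) in this assay. Among these compounds, this is the first step at this position read between two outright numbers, and it shows that a larger group, with an added six-membered aromatic ring of carbon only, causes no change beyond the scatter. The earlier steps shown here could not show this, because their second values are limits rather than numbers: the limit of > 50000 nM in this assay, at which 2 of the 4 values shown sit.

As far as these compounds go, whether a carboxylic acid or an amine at this amide-type nitrogen would move the number beyond the scatter stays open. A longer chain at the same place also remains untested among the compounds shown.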